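Swapping the aryl group on the amide-type nitrogen

The source may report more compounds than this note shows. Statements on the series, on what has been measured and on what is new or still open speak of the compounds shown alone.

Measured compounds:
Compound 1 `CC(=O)Nc1ccc(S(=O)(=O)Nc2cccc(-c3nc(-c4ccc(NC(=O)c5cccnc5)c(C(F)(F)F)c4)no3)c2)cc1`: > 10000 nM
Compound 2 `O=C(Nc1cccc(-c2nc(-c3ccc(NC(=O)c4cccnc4)cc3Cl)no2)c1)Nc1cccc(C(F)(F)F)c1`: 1900 nM
Compound 3 `O=C(Nc1cccc(-c2nc(-c3ccc(NC(=O)c4cccnc4)cc3Cl)no2)c1)Nc1cc(C(F)(F)F)cc(C(F)(F)F)c1`: 1900 nM

In a functional assay on MDA-MB-231 cells (Homo sapiens) for antiproliferative activity, read by MTT assay, with a stated time of 72 h (a lower number here means a stronger inhibitor, a higher number a weaker inhibitor), compound 2 gives 1900 nM. Compound 3 gives 1900 nM, and the step of no change at the digits printed from compound 2 to compound 3 (within the scatter) is within the scatter, so the two stand level. Compound 1 carries a different linker; in this assay compound 1 reaches only the limit of > 10000 nM, a bound rather than a number, as noted in the limit of > 10000 nM in this assay, at which 1 of the 3 values shown sits.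

Compound 4 `CS(=O)(=O)Nc1ccc(NC(=O)Nc2cccc(-c3nc(-c4ccc(NC(=O)c5cccnc5)cc4Cl)no3)c2)cc1Cl` has not yet been measured. It differs from compound 2 in one place: 3-chloro-4-(methanesulfonamido)phenyl in place of 3-(trifluoromethyl)phenyl on an amide-type nitrogen. Going by the values given here, the only measured step that touches the same ring is the one from compound 2 to compound 3, where adding a trifluoromethyl left the value unchanged within the scatter. Among the compounds with values here, no measured step tests a sulfonamide-bearing ring on this nitrogen, and compound 1, the only sulfonamide in the set, has its sulfonamide elsewhere and shows only a limit. The account therefore expects a step of a 1.3-fold higher number from compound 2 to compound 4 (0.12 log units; within the scatter) of no clear direction, with a wide range to reflect the untested group. For compound 4 the estimate in this assay is 2500 nM, between 800 nM and 8000 nM.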

Compound 4, half-maximal inhibitory concentration: 600 nM
Estimate against measurement, compound 4: 4.2-fold (0.62 log units) above; measured number below the stated range.
By their numbers in this assay, from the lowest: compound 4; then compounds 2 and 3 (each within the scatter of the next). At a limit, above all of these: compound 1.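

In this assay, replacing the aryl group on the amide-type nitrogen does move the value: 3-chloro-4-(methanesulfonamido)phenyl in place of 3-(trifluoromethyl)phenyl gives a 3.2-fold lower number from compound 2 to compound 4 (0.50 log units; beyond the scatter). The earlier step on this ring, no change at the digits printed from compound 2 to compound 3 (within the scatter), had shown no change on adding a second trifluoromethyl, so compound 4 is the first sign in this set that the value responds to what this ring carries, and it shows that a ring bearing a methanesulfonamido group is accepted on this nitrogen with a modest gain. No measured property among the data bears on this step, so the size of the gain stands here without an explanation.

The chloro and methanesulfonamido groups enter together and the trifluoromethyl leaves in the same step, so the compounds shown do not tell which of these changes carries the gain. As far as these compounds go, it also stays open whether another group in place of the methanesulfonamido group, such as a carboxylic acid, an amine or a longer alkylsulfonamide chain, would hold or extend the gain, and whether the chloro group is needed for it.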